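The source may report more compounds than this note shows. Statements on the series, on what has been measured and on what is new or still open speak of the compounds shown alone.

Compound 1 `O=C(O)c1cc(-c2cocn2)ccc1O` carries a five-membered aromatic ring on the core, and in a functional assay on the whole organism for inhibition, with Rattus norvegicus as the target, read by paw edema (on this read-out lower numbers stand for an effect already at smaller amounts and higher numbers for an effect only at larger amounts of compound), compound 1 gives 110 mg/kg. Within the data shown here, its only measured neighbour is compound 2 `O=C(O)c1cc(-n2ccnn2)ccc1O`, in which that ring is exchanged for another five-membered aromatic ring; in this assay compound 2 gives 150 mg/kg. Among the measured compounds shown here, the two numbers sit side by side, since the step of a 1.4-fold higher number from compound 1 to compound 2 (0.13 log units; within the scatter) stays within the scatter, so compound 1 stands on a par with compound 2 among the two values measured so far.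

Compound 3 `O=C(O)c1cc(-c2ncc[nH]2)ccc1O` is not yet measured. Compared with compound 1 it differs in one place: 1H-imidazol-2-yl in place of 1,3-oxazol-4-yl on an aromatic carbon. For the measured compounds named here, the one measured step that bears on this, the exchange of one five-membered ring with two hetero atoms for another a 1.4-fold higher number from compound 1 to compound 2 (0.13 log units; within the scatter), produced no change beyond the scatter. On that single precedent, the exchange leading to compound 3 is expected to give a step of similar size, that is, none beyond the scatter, as a 1.1-fold higher number from compound 1 to compound 3 (0.04 log units; within the scatter). Compound 3 is therefore estimated at 120 mg/kg, with a range from 60 mg/kg to 250 mg/kg.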

Compound 3, dose for half-maximal effect: 200 mg/kg
Estimate against measurement, compound 3: 1.7-fold (0.22 log units) below; low and high end bracket the measured number.
By their numbers in this assay, from the lowest: compounds 1, 2 and 3 (each within the scatter of the next).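

At this place, on an aromatic carbon para to a hydroxy group and meta to a carboxy group, 1,3-oxazol-4-yl has 0 hydrogen-bond donors and 2 hydrogen-bond acceptors, while 1H-imidazol-2-yl has 1 hydrogen-bond donor and 1 hydrogen-bond acceptor, and in this assay this exchange gives a 1.8-fold higher number from compound 1 to compound 3 (0.26 log units; within the scatter). The exchange of 1H-1,2,3-triazol-1-yl for 1H-imidazol-2-yl gives a 1.3-fold higher number from compound 2 to compound 3 (0.12 log units; within the scatter), so this read-out separates compound 3 from neither neighbour, even though the new ring differs from 1,3-oxazol-4-yl in its counts of donors and acceptors. No accompanying measurement offers an explanation for these numbers.

All three groups shown are five-membered aromatic rings on the shared core, so it remains open whether a group of another kind at this place, such as an amine, a phenyl ring or a longer alkyl chain, would give a step beyond the scatter. The carboxy group and the hydroxy group are also the same throughout, which leaves their part in these numbers open.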